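A few compounds are considered here, and "the series" means these few. Any claim that something is new, unique, unknown or untested is made for them only; others in the source may bear on it.

Working notes on the series.

Three compounds have numbers in a functional assay on MGC-803 cells (Homo sapiens) for cytotoxicity, read by MTT assay, with a stated time of 48 h; on this read-out lower numbers stand for stronger inhibition and higher numbers for weaker inhibition. Compound 1, `CC1=NN(C(=O)CN2CCC(c3ccccc3)CC2)C(c2ccccc2O)C1`, gives 12300 nM. Compound 2, `COc1ccccc1C1CC(C)=NN1C(=O)C[N+]1(C)CCCC1`, gives 12200 nM. Compound 3, `O=C(c1ccccc1Cl)N1N=C(c2cc3ccccc3oc2=O)CC1c1ccccc1`, gives 6640 nM. Compound 3 has the lowest of the three numbers, but its distance to compound 2 and its distance to compound 1 both lie within the scatter, so no order among the three can be read from these values.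

The next compound is compound 4, `CC1CC(C)CN(CC(=O)N2N=C(c3cc4ccccc4oc3=O)CC2c2ccccc2)C1`. It keeps the core of compound 3 and differs from it in one place: (3,5-dimethylpiperidin-1-yl)methyl in place of 2-chlorophenyl on a carbonyl carbon. Among the compounds with values here, compound 1 and compound 2 also carry a carbonyl joined to a methylene bearing a nitrogen ring, yet each differs from compound 3 in its core as well, so no measured pair isolates this change.

Within the data shown here, with no measured step of this kind to lean on, and with compound 1 at 12300 nM and compound 2 at 12200 nM sitting only within the scatter of compound 3, a step of a 1.4-fold higher number from compound 3 to compound 4 (0.13 log units; within the scatter) is expected, that is, nothing clearly beyond the scatter, if anything a slightly higher number. Compound 4 is therefore expected to give about 9000 nM in this assay, with a range from 3500 nM to 25000 nM.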

Compound 4, half-maximal inhibitory concentration: "not active" (no number reported)
For compound 4 the study gives words and no number; the estimate stays without a comparison.
By their numbers in this assay, from the lowest: compounds 3, 2 and 1 (each within the scatter of the next).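

Within the data shown here, compound 4 is reported in words only in this assay, with no number, so no step from compound 3 can be read. No measurement shown offers an explanation for this result. The compounds shown leave open how far (3,5-dimethylpiperidin-1-yl)methyl in place of 2-chlorophenyl on this carbonyl carbon moves the read-out.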